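Swapping a branched amine for a straight-chain one

A few compounds are considered here, and "the series" means these few. Any claim that something is new, unique, unknown or untested is made for them only; others in the source may bear on it.

Measured so far:
compound 1 `CCCN(CCC)c1nc(C)nc2c(-c3ccc(OC)nc3C)c(C)nn12`, 5.7 nM
compound 2 `CCC(CC)Nc1nc(C)nc2c(-c3ccc(OC)nc3C)c(C)nn12`, 3.1 nM
compound 3 `CCC(CC)Nc1nc(C)nc2c(-c3cnc(N(C)C)cc3C)c(C)nn12`, 24.8 nM

All three compounds share one core and were tested in an assay on cell membranes for displacement of a labelled ligand from corticotropin-releasing factor receptor 1 (Rattus norvegicus); a lower number here means a stronger inhibitor, a higher number a weaker inhibitor. Compound 2 has the lowest number of the three, but its lead over compound 1 is only a 1.8-fold lower number from compound 1 to compound 2 (0.26 log units; within the scatter), and that step lies within the scatter, so the two cannot be told apart. Compound 3 stands clearly apart, giving a number well above that of compound 2.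

Compound 4 `CCCCN(CC)c1nc(C)nc2c(-c3ccc(OC)nc3C)c(C)nn12` has not yet been measured. It differs from compound 2 at a single place: butyl(ethyl)amino in place of (pentan-3-yl)amino on an aromatic carbon. Among the compounds with values here, the one measured step that bears on this is the one from compound 1 to compound 2, where a dipropylamino group was replaced by a (pentan-3-yl)amino group and the number moved by a 1.8-fold lower number from compound 1 to compound 2 (0.26 log units; within the scatter), within the scatter. The change to compound 4 runs roughly the other way, back toward a dialkylamino group. For compound 4 the step from compound 2 is therefore expected to be small, a 1.6-fold higher number from compound 2 to compound 4 (0.21 log units; within the scatter), with no direction secure beyond the scatter. Compound 4 is estimated at 5 nM, in the range 2 nM to 13 nM.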

Compound 4, half-maximal inhibitory concentration: 4.9 nM
For compound 4 the middle estimate is 1.0-fold (0.01 log units) above the measured one; low and high end bracket the measured number.
By their numbers in this assay, from the lowest: compounds 2, 4 and 1 (each within the scatter of the next); then compound 3.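

In this assay the swap to butyl(ethyl)amino gives a 1.6-fold higher number from compound 2 to compound 4 (0.20 log units; within the scatter) even though it removes the one hydrogen-bond donor of (pentan-3-yl)amino and adds one heavy atom, so among these compounds the amine hydrogen at this place, between two ring nitrogen atoms, is not required for a number in this range. The two chains on the nitrogen also need not match, as the change from dipropylamino to butyl(ethyl)amino gives a 1.2-fold lower number from compound 1 to compound 4 (0.07 log units; within the scatter) and so leaves branched, equal-chain and unequal-chain amines all within the scatter of one another on this core. Nothing measured here explains why these three amines read so alike.

On these data alone, how far this tolerance extends remains open, for example whether an amine with its nitrogen held in a ring, such as morpholine, or a chain carrying an ether oxygen, such as bis(2-methoxyethyl)amino, would stay in the same range. As far as these compounds go, it is also open whether butyl(ethyl)amino would read the same way on the dimethylamino-bearing side group of compound 3, where only (pentan-3-yl)amino appears.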